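Swapping the aryl on the triazole nitrogen: compound 3 to compound 4

A few compounds are considered here, and "the series" means these few. Any claim that something is new, unique, unknown or untested is made for them only; others in the source may bear on it.

Three ureas sharing one core have been measured in a functional assay on HepG2 cells (Homo sapiens) for inhibition, read by MTT assay, with a stated time of 72 h; on this read-out higher numbers stand for weaker inhibition and lower numbers for stronger inhibition. Compound 1 `N#Cc1ccc(-n2cc(COc3cccc(NC(=O)Nc4ccc(Cl)c(C(F)(F)F)c4)c3)nn2)cc1` gives 2980 nM, compound 2 `CC(C)c1ccccc1-n1cc(COc2cccc(NC(=O)Nc3ccc(Cl)c(C(F)(F)F)c3)c2)nn1` gives 1900 nM, and compound 3 `O=C(Nc1cccc(OCc2cn(-c3ccc(F)cc3)nn2)c1)Nc1ccc(Cl)c(C(F)(F)F)c1` gives 1350 nM. Compound 3 carries the lowest number of the three, though compound 2 sits within the scatter of it, as a 1.4-fold lower number from compound 2 to compound 3 (0.15 log units; within the scatter) shows; only compound 1 lies clearly apart, with a 2.2-fold lower number from compound 1 to compound 3 (0.34 log units; beyond the scatter).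

Compound 4 `O=C(Nc1cccc(OCc2cn(-c3ccccc3I)nn2)c1)Nc1ccc(Cl)c(C(F)(F)F)c1` has not yet been measured. The change from compound 3 is 2-iodophenyl in place of 4-fluorophenyl on an aromatic nitrogen. Within the data shown here, the steps that bear on this are the earlier swaps of the aryl on the same nitrogen: a 1.6-fold lower number from compound 1 to compound 2 (0.20 log units; within the scatter) and a 1.4-fold lower number from compound 2 to compound 3 (0.15 log units; within the scatter), both within the scatter, and the modest 2.2-fold lower number from compound 1 to compound 3 (0.34 log units; beyond the scatter). None of these aryl changes moved this assay far, and compound 2, whose 2-isopropylphenyl also carries a single group, gave 1900 nM, within the scatter of compound 3. Compound 4 is therefore expected to show a step of a 1.4-fold higher number from compound 3 to compound 4 (0.15 log units; within the scatter), within the scatter. The estimate for compound 4 is 1900 nM, with a range from 950 nM to 3800 nM.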

Compound 4, half-maximal inhibitory concentration: 2870 nM
The estimate for compound 4 lay 1.5-fold (0.18 log units) below the measured number; the range from low to high includes it.
By their numbers in this assay, from the lowest: compounds 3, 2, 4 and 1 (each within the scatter of the next, the first and the last beyond it).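

In this assay, 2-iodophenyl in place of 4-fluorophenyl on this aromatic nitrogen gives a 2.1-fold higher number from compound 3 to compound 4 (0.33 log units; beyond the scatter) as a second modest step beyond the scatter at this position. Iodo in place of isopropyl gives only a 1.5-fold higher number from compound 2 to compound 4 (0.18 log units; within the scatter) and 2-iodophenyl in place of 4-cyanophenyl only a 1.0-fold lower number from compound 1 to compound 4 (0.02 log units; within the scatter) so that compound 3 now stands clearly apart from two of the other aryl compounds, while compound 2 remains within the scatter of it. No experimental information bears on why these aryl groups differ so little.

The compounds shown leave open whether an amine or a carboxylic acid on this aryl ring would move the number further than these groups did. They also leave open whether a longer chain in place of the aryl ring would be tolerated in this assay.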